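A few compounds are considered here, and "the series" means these few. Any claim that something is new, unique, unknown or untested is made for them only; others in the source may bear on it.

In a functional assay on K562 cells (Homo sapiens) for cytotoxicity, read by MTT assay, with a stated time of 72 h (on this read-out higher numbers stand for weaker inhibition and lower numbers for stronger inhibition), the measured compounds are:

compound 1, `CSCC[C@H](NC1=CC(=O)C=C(C[C@]2(C)[C@@H](C)CC[C@]3(C)C(C)=CCC[C@@H]23)C1=O)C(=O)O`, which gives 13600 nM
compound 2, `CC1=CCC[C@H]2[C@](C)(CC3=CC(=O)C=C(N[C@@H](C)C(=O)O)C3=O)[C@@H](C)CC[C@]12C`, which gives 15800 nM
compound 3, `C[C@H](NC1=CC(=O)C=C(C(C)(C)C)C1=O)C(=O)O`, which gives 77600 nM

Compound 2 and compound 1 share a core and differ only by (methylsulfanyl)methyl in place of hydrogen on a saturated chain carbon, two bonds along the chain from an amine nitrogen and a carbonyl carbon. That change made a 1.2-fold lower number from compound 2 to compound 1 (0.07 log units; within the scatter). Compound 3 carries a different core; the difference between the two cores is not broken down here. Compound 3 shows the highest number of the three, beyond the scatter from both compound 2 and compound 1.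

Compound 4, `CSCC[C@H](NC1=CC(=O)C=C(C(C)(C)C)C1=O)C(=O)O`, has not yet been measured. Within the data shown here, it arises from compound 3 by (methylsulfanyl)methyl in place of hydrogen on a saturated chain carbon, two bonds along the chain from an amine nitrogen and a carbonyl carbon, the same change at the same place as the one from compound 2 to compound 1. Because that earlier change gave a 1.2-fold lower number from compound 2 to compound 1 (0.07 log units; within the scatter), compound 4 is expected to stay close to compound 3, with a step of about a 1.2-fold lower number from compound 3 to compound 4 (0.08 log units; within the scatter) in this assay. The estimate for compound 4 is 65000 nM, expected to fall between 28000 nM and 150000 nM.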

Compound 4, half-maximal inhibitory concentration: 88500 nM
Beside the measured number, compound 4's estimate is 1.4-fold (0.13 log units) below it; the range from low to high includes it.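

In this assay, putting (methylsulfanyl)methyl in place of hydrogen on the saturated chain carbon gave a 1.1-fold higher number from compound 3 to compound 4 (0.06 log units; within the scatter). Set beside the earlier step, the change behaves alike on both cores: the same change on two cores in this assay, a 1.2-fold lower number (0.07 log units; within the scatter) from compound 2 to compound 1 and a 1.1-fold higher number (0.06 log units; within the scatter) from compound 3 to compound 4, 1.3-fold (0.12 log units) apart, within the scatter of two such steps. This shows that on these two cores the change leaves the number within the scatter, so its small size carries over from one core to the other, but it does not show the same for any further core or explain why the change does so little.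

The compounds shown leave open whether a different group on that same carbon, such as benzyl or a longer chain ending in an amine, would move the number beyond the scatter.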